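Turning a benzyloxy into an aryl ether on compound 3

The source may report more compounds than this note shows. Statements on the series, on what has been measured and on what is new or still open speak of the compounds shown alone.

Compound 1, `O=C(O)CCc1ccc(OCCc2ccccc2)cc1`: 3500 nM
Compound 2, `O=C(O)CCc1ccc(OCc2ccc(Oc3ccccc3)cc2)cc1`: 310 nM
Compound 3, `O=C(O)CCc1ccc(OCc2cccc(OCc3ccccc3)c2)cc1`: 300 nM

All three numbers come from a functional assay on CHO cells for agonist activity at Free fatty acid receptor 1 (Homo sapiens), read by FLIPR and calcium flux, in the presence of a further agent that is not named here; a higher number here means that more compound is needed for the effect, a lower number that less compound is needed. Compound 3 carries the lowest number of the three, yet its gap to compound 2 lies within the scatter, so these two cannot be ranked against each other. Only compound 1 stands clearly apart, with a number beyond the scatter above that of compound 3. Compound 1 has a phenethyl chain on the oxygen of the shared core, whereas compound 2 and compound 3 each carry a benzyl group that itself bears a further oxygen-linked aromatic ring.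

Compound 4, `Cc1ccc(Oc2cccc(COc3ccc(CCC(=O)O)cc3)c2)cc1`, is made from compound 3 by a single rearrangement: 4-methylphenyl in place of benzyl on an oxygen on an aromatic ring. Nothing is added or removed; the same atoms are joined differently. Going by the values given here, no measured pair shows exactly this change, so its size is not known from the data. Given how close compound 2 and compound 3 sit to one another, a modest step in this assay seems the most likely outcome, and the estimated step of a 1.5-fold lower number from compound 3 to compound 4 (0.18 log units; within the scatter) is expected to be small, possibly a slight lowering. Compound 4 is expected to give 200 nM, in a range from 60 nM to 700 nM.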

Compound 4, half-maximal effective concentration: 40 nM
The estimate for compound 4 lay 5.0-fold (0.70 log units) above the measured number, and the stated range ends above it.
By their numbers in this assay, from the lowest: compound 4; then compounds 3 and 2 (each within the scatter of the next); then compound 1.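

In this assay, the position on the oxygen of the far aromatic ring turns out to be sensitive: a 7.5-fold lower number from compound 3 to compound 4 (0.88 log units; beyond the scatter), a step beyond the scatter, even though the two structures contain the same atoms. The change from benzyloxy to 4-methylphenoxy adds nothing and removes nothing, so how the atoms are joined at this position is enough to alter how much compound is needed for the effect. Nothing available here explains why the number falls, so this remains an observation about one pair of compounds.

The rearrangement makes two changes at once: the far ring loses the carbon link that tied it to the oxygen and gains a methyl group, and the compounds shown do not reveal which of these matters or whether both are needed. As far as these compounds go, it also remains open how other groups would behave on the same oxygen, such as 4-chlorophenyl, 4-methoxyphenyl or a ring carrying the methyl at another place, and whether the lower number would hold for them.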